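The compounds below may be only part of what the source reports. "The series", "measured", "known", "first", "only" and "open" are said of these compounds alone.

Measured so far in a toxicity assay on MT2 cells (Homo sapiens) for cytotoxicity, read by MTT assay; a higher number here means that more compound is tolerated, a lower number that less compound is tolerated:
compound 1 `N#Cc1ccc2c(Cl)cc(Oc3ccccc3OCCn3ccc(=O)[nH]c3=O)cc2c1`: 12000 nM
compound 2 `Cc1cc(Oc2ccccc2OCCn2ccc(=O)[nH]c2=O)cc2cc(C#N)ccc12`: 6000 nM
compound 3 `N#Cc1ccc2c(F)cc(Oc3ccccc3OCCn3ccc(=O)[nH]c3=O)c(Cl)c2c1`: > 100000 nM

For compound 3 the value shown is a limit of this assay and not a number; it sits at the limit of > 100000 nM in this assay, at which 1 of the 3 values shown sits. The two numbers, from compound 1 and compound 2, differ by a 2.0-fold lower number from compound 1 to compound 2 (0.30 log units; within the scatter), a step within the scatter.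

Compound 4 `Cc1c(Oc2ccccc2OCCn2ccc(=O)[nH]c2=O)cc(F)c2ccc(C#N)cc12` differs from compound 3 in one place: methyl in place of chloro on an aromatic carbon. Among the measured compounds shown here, the only measured step of this same kind is a 2.0-fold lower number from compound 1 to compound 2 (0.30 log units; within the scatter), which stayed within the scatter, so no shift beyond the scatter is expected here, and the step of a number no higher from compound 3 to compound 4 (the limit leaves the size open) is estimated. Compound 4 is thus expected to give about 100000 nM, between 50000 nM and 200000 nM, quite possibly again reported only as a limit.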

Compound 4, half-maximal cytotoxic concentration: > 100000 nM
Compound 4: a limit, no number; the forecaster's own chance of this, stated with the estimate: 70%; the middle value lies on the limit itself.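

Compound 3 and compound 4 both give only a limit and not a number, so no step between them can be read: the limit of > 100000 nM in this assay, at which 2 of the 4 values shown sit.

The compounds shown leave open how much of either compound is actually tolerated, and so whether methyl in place of chloro matters in this pair.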